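A few compounds are considered here, and "the series" means these few. Any claim that something is new, unique, unknown or untested is made for them only; others in the source may bear on it.

Compound 1 `CC(C)(C)c1nnc2nnc(N3CCCC3)nn12`: 12500 nM
Compound 2 `C1CCC(c2nnc3nnc(N4CCCC4)nn23)CC1`: 22000 nM
Compound 3 `c1ccc(-c2nnc3nnc(N4CCCC4)n3n2)cc1`: > 100000 nM, a limit of the assay.

The three share one core and differ in the group on an aromatic carbon. In a functional assay on BeWo cells (Homo sapiens) for cytotoxicity, read by MTT assay, with a stated time of 72 h (on this read-out lower numbers stand for stronger inhibition and higher numbers for weaker inhibition), compound 2 is one of two numbers; the other belongs to compound 1, and the step of a 1.8-fold higher number from compound 1 to compound 2 (0.25 log units; within the scatter) lies within the scatter, so the two are not distinguished. Compound 3 returns only (the limit of > 100000 nM in this assay, at which 1 of the 3 values shown sits).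

Compound 4 `CC(C)c1nnc2nnc(N3CCCC3)nn12` differs from compound 2 by isopropyl in place of cyclohexyl on an aromatic carbon. Going by the values given here, the one measured step that bears on this, cyclohexyl for tert-butyl, stayed within the scatter, so a smaller alkyl is expected to move this assay little, perhaps toward a slightly lower number. Compound 4 is estimated at 15000 nM, with a range from 6000 nM to 40000 nM. For compound 4 the expected step is a 1.5-fold lower number from compound 2 to compound 4 (0.17 log units; within the scatter).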

Compound 4, half-maximal inhibitory concentration: 3430 nM
Compound 4: middle estimate off by 4.4-fold (0.64 log units), on the high side, outside the stated range (below it).
By their numbers in this assay, from the lowest: compound 4; then compounds 1 and 2 (each within the scatter of the next). At a limit, above all of these: compound 3.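

In this assay, this position responds to the alkyl group after all: a 6.4-fold lower number from compound 2 to compound 4 (0.81 log units; beyond the scatter), and a 3.6-fold lower number from compound 1 to compound 4 (0.56 log units; beyond the scatter). Isopropyl therefore stands apart from both larger groups, and the absence of a ring does not set it apart, as tert-butyl has none either. Nothing shown accounts for these steps.

From the compounds shown here alone, it remains open whether methyl or ethyl on this aromatic carbon would give a lower number still. Going by these compounds, it is also open how an amine or a carboxylic acid would behave there.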